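Hydrogen in place of fluoro on the aryl ring of compound 2

The source may report more compounds than this note shows. Statements on the series, on what has been measured and on what is new or still open speak of the compounds shown alone.

Compound 2 `O=c1oc2ccccc2c2nc3c(ccc4cc[nH]c43)c(-c3ccc(F)cc3)c12` carries the shared core with a fluorophenyl arm; in a functional assay on B16-F10 cells (Mus musculus) for cytotoxicity (a higher number here means a weaker inhibitor, a lower number a stronger inhibitor), compound 2 gives 70700 nM. Compound 1 `O=c1oc2ccccc2c2nc3c(ccc4cc[nH]c43)c(-c3ccc(O)cc3)c12` bears a hydroxyphenyl arm in its place, and in this assay compound 1 gives 70700 nM, so that the step of no change at the digits printed from compound 1 to compound 2 (within the scatter) is flat. Compound 3 `O=c1cc(O)c2cc(F)ccc2o1` is a much smaller molecule without the fused core, and in this assay compound 3 gives 70700 nM; its value and that of compound 2 sit together within the scatter, as do all three measured values, so compound 2 stands level with both.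

Compound 4 `O=c1oc2ccccc2c2nc3c(ccc4cc[nH]c43)c(-c3ccccc3)c12` is the next case. Its difference from compound 2 is hydrogen in place of fluoro on an aromatic carbon. For the measured compounds named here, the only measured step that touches the same carbon is no change at the digits printed from compound 1 to compound 2 (within the scatter), which showed nothing beyond the scatter. Two changes of the group on this carbon have left the read-out unmoved, and the compound lacking the whole core, compound 3, reads the same as well; nothing in the series points to a shift in either direction.

The step of no change at the digits printed from compound 2 to compound 4 (within the scatter) is therefore expected to stay within the scatter. For compound 4 the expected value is 70700 nM, with a range from 35000 nM to 141000 nM.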

Compound 4, half-maximal inhibitory concentration: 70700 nM
Compound 4: middle estimate and measured number agree at the digits printed, and the stated range covers the measured number.
By their numbers in this assay, from the lowest: compounds 1, 2, 3 and 4 (each within the scatter of the next).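

At the carbon para to a large group, the change from 4-fluorophenyl to phenyl gives no change at the digits printed from compound 2 to compound 4 (within the scatter) in this assay and hydrogen in place of hydroxy gives no change at the digits printed from compound 1 to compound 4 (within the scatter) for the same carbon. The earlier step compared only two substituted arms, whereas the series now includes the bare phenyl, so hydroxy, fluoro and hydrogen on this carbon all read alike in this assay and removing the substituent altogether leaves the read-out as flat as exchanging it. No supporting measurement bears on why the three compounds read alike.

What a group of a different kind would do on this carbon stays open, since an amine, a carboxylic acid or a longer chain such as butoxy is not among the compounds shown, and three closely related arms cannot say whether this position can move the read-out at all. Also open, as far as these compounds go, is whether a change elsewhere on the shared core would shift the number, as every step read so far falls on this one carbon.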